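The source may hold more compounds than are shown below. What is called first, only, known or untested is meant among the compounds shown, and "the series" means these compounds.

Measured so far in a physicochemical assay for lipophilicity, read by HPLC, at pH 7.5; on this read-out lower numbers stand for lower lipophilicity and higher numbers for higher lipophilicity:

- compound 1, `CCOc1ccccc1-c1ccc(-c2nc3cnccc3c(NC(COC)C(N)=O)c2C#N)cc1`: 2.8
- compound 2, `CC[C@H](Nc1c(C#N)c(-c2ccc(Br)cc2)nc2cnccc12)C(N)=O`: 2.3

Of the two numbers, compound 1 stands highest. The nearest number belongs to compound 2, which reads lower by an amount beyond the usual scatter; the two compounds differ in more than one place, so this gap is taken only as what the two values show and not as a step of its own.

Compound 3 is `CCOc1ccccc1-c1ccc(-c2nc3cnccc3c(N[C@H](CC(C)C)C(N)=O)c2C#N)cc1` and has not yet been measured in this assay. It differs from compound 1 in one place: 1-carbamoyl-3-methylbutyl in place of 1-carbamoyl-2-methoxyethyl on a nitrogen on an aromatic ring. The entering group is the larger of the two, and the methoxy oxygen of the leaving group is absent from it.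

Among the compounds with values here, no measured pair in this set shows the same exchange, so the size of the step can rest only on the change itself. An upward step a number 1.00 log units higher from compound 1 to compound 3 (beyond the scatter) is expected, larger than the scatter. On that basis compound 3 is estimated at 3.8, with a range from 3.3 to 4.3.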

Compound 3, distribution coefficient: 3.4
Beside the measured number, compound 3's estimate is 0.40 log units above it; low and high end bracket the measured number.
By their numbers in this assay, from the lowest: compound 2; then compound 1; then compound 3.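

In this assay, within the data shown here, this place on the nitrogen on an aromatic ring can be read apart from the rest of the molecule for the first time: 1-carbamoyl-3-methylbutyl in place of 1-carbamoyl-2-methoxyethyl gives a number 0.60 log units higher from compound 1 to compound 3 (beyond the scatter) and leaves the remainder of compound 1 unchanged. The step is modest but beyond the usual scatter, so an exchange confined to this side chain is enough to move the read-out by a measurable amount. The exchange alters several things at once, as the entering group is the larger, lacks the methoxy oxygen and carries a defined stereocentre, and nothing available assigns the step to any one of these or gives a cause for it.

Going by these compounds, how much of the step goes with the methoxy oxygen and how much with the larger chain stays open, and a 1-carbamoyl-3-methoxypropyl group on the same nitrogen would bear on that split. Also open, on these data alone, is how the read-out would respond to a carboxylic acid in place of the carbamoyl group, or to an amine at the end of the chain.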